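A few compounds are considered here, and "the series" means these few. Any claim that something is new, unique, unknown or untested is made for them only; others in the source may bear on it.

Values in a functional assay on MCF7 cells (Homo sapiens) for antiproliferative activity, read by sulforhodamine B assay, with a stated time of 72 h; on this read-out higher numbers stand for weaker inhibition and lower numbers for stronger inhibition:
compound 1 `COc1ncc(-c2ccc3ncnc(NCCN(C)C)c3c2)cc1NS(C)(=O)=O`: 14700 nM
compound 2 `COc1ncc(-c2ccc3ncnc(NCCN(C)C)c3c2)cc1NS(=O)(=O)c1ccc(F)cc1`: 1230 nM
compound 3 `COc1ncc(-c2ccc3ncnc(NCc4ccncc4)c3c2)cc1NS(=O)(=O)c1ccc(F)cc1F`: 22500 nM

Compound 3 at 22500 nM and compound 1 at 14700 nM lie within the scatter of each other, while compound 2 at 1230 nM has a far lower number than both.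

Compound 4 `COc1ncc(-c2ccc3ncnc(NCCN(C)C)c3c2)cc1NS(=O)(=O)c1ccc(F)cc1F` is not yet measured. It keeps the sulfonyl substituent of compound 3 and changes the amine chain: (dimethylamino)methyl in place of pyridin-4-yl on a saturated chain carbon bound to a nitrogen on an aromatic ring. Put another way, (pyridin-4-yl)methyl gives way to 2-(dimethylamino)ethyl.

Among the measured compounds shown here, no measured step covers this exchange directly. For the measured compounds named here, the only step available, a 12-fold lower number from compound 1 to compound 2 (1.08 log units; beyond the scatter), lies on the sulfonyl sulfur, so it bears on the chain change only indirectly. It does show how far the number can move within the 2-(dimethylamino)ethyl compounds. Compound 2 has the same chain as compound 4 and differs from it only in the fluorine substitution of the aryl group on the sulfonyl sulfur, and compound 2 gives 1230 nM. On that basis, a large move to a lower number is expected in this assay, estimated as a 20-fold lower number from compound 3 to compound 4 (1.31 log units; beyond the scatter). Compound 4 is expected at 1100 nM, with an estimated range of 350 nM to 3500 nM.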

Compound 4, half-maximal inhibitory concentration: 1020 nM
Compound 4: the middle estimate sits 1.1-fold (0.03 log units) above what was measured, and the stated range covers the measured number.
By their numbers in this assay, from the lowest: compounds 4 and 2 (each within the scatter of the next); then compounds 1 and 3 (each within the scatter of the next).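

Working notes: in this assay the amine chain can now be read directly, with the 2,4-difluorophenyl group on the sulfonyl sulfur held fixed: 2-(dimethylamino)ethyl in place of (pyridin-4-yl)methyl gives a 22-fold lower number from compound 3 to compound 4 (1.34 log units; beyond the scatter) as a large step, so the number depends strongly on this position and not only on the sulfonyl substituent. On the sulfonyl sulfur, the added fluoro on the aromatic carbon gives a 1.2-fold lower number from compound 2 to compound 4 (0.08 log units; within the scatter) and makes no readable difference, whereas 2,4-difluorophenyl in place of methyl gives a 14-fold lower number from compound 1 to compound 4 (1.16 log units; beyond the scatter) as a large step, so within the 2-(dimethylamino)ethyl compounds both aryl groups stand clearly apart from methyl. Nothing available accounts for the size of either step.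

Still open, on these data alone, is which part of the chain exchange matters, since the terminal dimethylamino group, the chain length and the loss of the pyridine ring all change together; a 3-(dimethylamino)propyl chain, a 2-(morpholin-4-yl)ethyl chain or a 2-(pyridin-4-yl)ethyl chain would begin to separate them. Also open is whether the sulfonyl substituents rank the same way on the (pyridin-4-yl)methyl chain, where only the 2,4-difluorophenyl group is shown.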